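Aryl amide to pyridyl amide on a shared core

The source may hold more compounds than are shown below. What is called first, only, known or untested is meant among the compounds shown, and "the series" means these compounds.

Measured compounds:
compound 1 `Cc1noc(C)c1-c1cnc(N)c(Oc2ccc(C(=O)NC3CCCCC3)cc2)n1` — 21600 nM
compound 2 `Cc1noc(C)c1-c1cnc(N)c(Oc2ccc(C(=O)Nc3ccc(Cl)cc3)cc2)n1` — 1920 nM

Within the data shown here, in a functional assay on LoVo cells (Homo sapiens) for inhibition, read by MTT assay, with a stated time of 72 h (a lower number here means a stronger inhibitor, a higher number a weaker inhibitor), compound 2 gives 1920 nM, the lowest of the two numbers so far; its nearest neighbour is compound 1, which gives 21600 nM. Compound 3 `Cc1noc(C)c1-c1cnc(N)c(Oc2ccc(C(=O)Nc3cc(Cl)ccn3)cc2)n1` differs from compound 2 by 4-chloropyridin-2-yl in place of 4-chlorophenyl on an amide-type nitrogen. Among the measured compounds shown here, the only measured step, an 11-fold lower number from compound 1 to compound 2 (1.05 log units; beyond the scatter), concerns the same position but a different exchange, and no measured pair separates a ring nitrogen from a carbon at that place. The expected step of a 1.3-fold higher number from compound 2 to compound 3 (0.11 log units; within the scatter) is therefore none beyond the scatter. Compound 3 is estimated at 2500 nM, within 900 nM to 7000 nM.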

Compound 3, half-maximal inhibitory concentration: > 100000 nM
Compound 3 gave a limit, no number; the forecaster's own chance of this, stated with the estimate: 5%; middle value at least 40-fold (1.60 log units) away from the limit.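

In this assay, the group on the amide-type nitrogen proves sensitive to a change of one ring atom: 4-chloropyridin-2-yl in place of 4-chlorophenyl gives an at least 52-fold higher number from compound 2 to compound 3 (1.71 log units; beyond the scatter). Put in place of cyclohexyl, the same group gives an at least 4.6-fold higher number from compound 1 to compound 3 (0.66 log units; beyond the scatter), so an aromatic ring at this place does not by itself bring the gain seen with compound 2. The reading for compound 3 is a limit, not a number: the limit of > 100000 nM in this assay, at which 1 of the 3 values shown sits.

The compounds shown leave open how 4-chloropyridin-3-yl or 4-methoxyphenyl on this nitrogen would read. They also leave open whether an unsubstituted pyridin-2-yl would read as compound 3 does.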